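The compounds below may be only part of what the source reports. "The series", "measured", "known", "first", "only" and "open" are said of these compounds alone.

Values measured in an ADME assay on MT4 cells (Homo sapiens) for cytotoxicity, read by MTT assay, with a stated time of 4 days; a higher number here means that more compound is tolerated, a lower number that less compound is tolerated:

- Compound 1 `COc1ccc(-c2oc3ccc(NC(C)=O)cc3c(=O)c2O)cc1`: 98700 nM
- Compound 2 `COc1c(-c2ccccc2)oc2ccc(NC(C)=O)cc2c1=O`: 200000 nM
- Compound 3 `COc1cccc(-c2oc3ccc(NC(C)=O)cc3c(=O)c2OC)c1`: 369000 nM

Compound 3, at 369000 nM, lies within the usual scatter of compound 2. Compared with compound 1, it gives a higher number, and that gap lies beyond the scatter. Thus, within this small set, compound 3 sits at the well-tolerated end, level with compound 2 in practical terms.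

The next compound to be measured is compound 4 `COc1ccc(-c2oc3ccc(NC(C)=O)cc3c(=O)c2OC)cc1`. It has the same atoms as compound 3, joined differently: 4-methoxyphenyl in place of 3-methoxyphenyl on an aromatic carbon. The methoxy group therefore stays on the phenyl ring, but 4-methoxyphenyl stands in place of 3-methoxyphenyl.

Among the compounds with values here, only one measured step bears on this change. Methoxy in place of hydrogen on an aromatic carbon gave a 1.8-fold higher number from compound 2 to compound 3 (0.27 log units; within the scatter). Within the data shown here, no measured step shows a methoxy group changing place on that ring, so the evidence is indirect. Since adding the group did not move this assay beyond the scatter, no step beyond the scatter is expected from relocating it.

The estimated change is a 1.4-fold lower number from compound 3 to compound 4 (0.15 log units; within the scatter), which is expected to stay within the scatter. For compound 4 the expected value is 260000 nM, with an estimated range from 110000 nM to 500000 nM.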

Compound 4, half-maximal cytotoxic concentration: 369000 nM
For compound 4 the middle estimate is 1.4-fold (0.15 log units) below the measured one, and the stated range covers the measured number.
By their numbers in this assay, from the lowest: compound 1; then compounds 2, 3 and 4 (each within the scatter of the next).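

In this assay, within the data shown here, the methoxy group changes place on the phenyl ring for the first time, and 4-methoxyphenyl in place of 3-methoxyphenyl gives no change at the digits printed from compound 3 to compound 4 (within the scatter) in this series; adding the group as 4-methoxyphenyl gives a 1.8-fold higher number from compound 2 to compound 4 (0.27 log units; within the scatter) as well, so neither placement carries the number beyond the scatter. Among these compounds, the new compound also gives the first comparison that differs only at the oxygen on the shared core, where methyl in place of hydrogen gives a 3.7-fold higher number from compound 1 to compound 4 (0.57 log units; beyond the scatter) and is the only step of the three beyond the scatter, though a modest one. Nothing in the data shown accounts for either result.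

The compounds shown do not tell whether the step at the core oxygen would recur with 3-methoxyphenyl or plain phenyl on the core, since that oxygen carries hydrogen only in compound 1. They also leave open how a longer chain such as ethyl on that oxygen, or an amine or a carboxylic acid on the phenyl ring, would read in this assay for this series.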